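A few compounds are considered here, and "the series" means these few. Any claim that something is new, unique, unknown or untested is made for them only; others in the source may bear on it.

Compound 1 `Cn1ncc(Cl)c1-c1cc(C(=O)N[C@@H]2CN[C@H](CCN3CCC(O)CC3)C[C@H]2c2ccc(Cl)c(Cl)c2)oc1Cl` gives 1140 nM in a functional assay on LNCaP cells (Homo sapiens) for antiproliferative activity; on this read-out higher numbers stand for weaker inhibition and lower numbers for stronger inhibition.
Compound 2 `Cn1ncc(Cl)c1-c1cc(C(=O)N[C@@H]2CN[C@H](CCCO)C[C@H]2c2ccc(Cl)c(Cl)c2)oc1Cl` gives 210 nM.
Compound 3 `Cn1ncc(Cl)c1-c1cc(C(=O)N[C@@H]2CN[C@H](CC(N)=O)C[C@H]2c2ccc(Cl)c(Cl)c2)oc1Cl` gives 160 nM.

Compound 3 shows the lowest of the three numbers, but its gap to compound 2, a 1.3-fold lower number from compound 2 to compound 3 (0.12 log units; within the scatter), lies within the scatter, so the two cannot be ordered. Compound 1 is set apart: a 7.1-fold lower number from compound 1 to compound 3 (0.85 log units; beyond the scatter).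

Compound 4 `CN(C)CC[C@@H]1C[C@@H](c2ccc(Cl)c(Cl)c2)[C@H](NC(=O)c2cc(-c3c(Cl)cnn3C)c(Cl)o2)CN1` differs from compound 3 by one change: (dimethylamino)methyl in place of carbamoyl on a saturated chain carbon bound to a saturated ring carbon. Among the measured compounds shown here, the steps that bear on it are a 5.4-fold lower number from compound 1 to compound 2 (0.73 log units; beyond the scatter) and a 7.1-fold lower number from compound 1 to compound 3 (0.85 log units; beyond the scatter), in which the 4-hydroxypiperidin-1-yl group of compound 1 gave way to smaller groups. Compound 4 carries a nitrogen-bearing chain group again, so a modest rise is expected, a 3.1-fold higher number from compound 3 to compound 4 (0.49 log units; beyond the scatter), though smaller than the return to compound 1. Compound 4 is therefore estimated at 500 nM, between 150 nM and 1500 nM.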

Compound 4, half-maximal inhibitory concentration: 1930 nM
The estimate for compound 4 lay 3.9-fold (0.59 log units) below the measured number; measured number outside the range, above it.
By their numbers in this assay, from the lowest: compounds 3 and 2 (each within the scatter of the next); then compounds 1 and 4 (each within the scatter of the next).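

Replacing carbamoyl with (dimethylamino)methyl at this position weakens inhibition sharply in this assay (a 12-fold higher number from compound 3 to compound 4 (1.08 log units; beyond the scatter)), and replacing the hydroxymethyl end of the chain with dimethylamino does much the same (a 9.2-fold higher number from compound 2 to compound 4 (0.96 log units; beyond the scatter)). Dimethylamino also cannot be told apart from the larger 4-hydroxypiperidin-1-yl (a 1.7-fold higher number from compound 1 to compound 4 (0.23 log units; within the scatter)), so a smaller group alone did not bring the number down: here, both chains ending in an amine sit high, and the other two sit low. No supporting measurement explains this gap. From the compounds shown here alone, whether a primary amine, a carboxylic acid or a longer chain ending in dimethylamino would behave like compound 3 or compound 4 remains open.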